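Carbamoyl to hydroxymethyl at an assay limit

The source may hold more compounds than are shown below. What is called first, only, known or untested is meant among the compounds shown, and "the series" means these compounds.

Compound 1 `Cc1noc(-c2nc(C)c3c(c2N)C(=O)N(Cc2ccc(C#N)cc2)C3=O)n1` and compound 2 `Cc1noc(-c2nc(C)c3c(c2N)C(=O)N(Cc2ccc(C(N)=O)cc2)C3=O)n1` differ by carbamoyl in place of cyano on an aromatic carbon. In a physicochemical assay for solubility, using the shake flask method, in simulated intestinal fluid, measured as kinetic solubility, with a stated time of 2 h, at 25 degrees C, at pH 6.5 (on this read-out lower numbers stand for lower solubility and higher numbers for higher solubility), compound 1 gives < 5000 nM, which is a limit and not a number. In this assay compound 2 gives < 5000 nM, again only a limit. The whole record on this read-out is therefore (the limit of < 5000 nM in this assay, at which 2 of the 2 values shown sit), and compound 2 has no exact standing within it.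

Compound 3 `Cc1noc(-c2nc(C)c3c(c2N)C(=O)N(Cc2ccc(CO)cc2)C3=O)n1` carries hydroxymethyl in place of carbamoyl on an aromatic carbon, para to a large group: hydroxymethyl in place of carbamoyl on an aromatic carbon. Going by the values given here, the one measured step that bears on this change is a step that the two limits leave unreadable from compound 1 to compound 2. That step offers neither a size nor a direction to carry over, so no shift beyond the scatter is expected in this assay. The expected step is a step that the limit leaves unreadable from compound 2 to compound 3, an estimate that favours neither direction. For compound 3 the estimated value is 3000 nM, with an expected range from 800 nM to 10000 nM. A further limit, rather than a number, is the likeliest report.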

Compound 3, solubility: < 5000 nM
Compound 3 ended at the assay's limit; the forecaster's own chance of this, stated with the estimate: 75%; the middle value does not contradict the limit.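

In this assay compound 3 gives < 5000 nM, which is a limit and not a number. No new step can be read between compound 3 and either compound 1 or compound 2, and the record now reads: the limit of < 5000 nM in this assay, at which 3 of the 3 values shown sit. Where the true solubility of these three compounds lies, and whether they differ from one another, stays open.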